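Pyridin-2-yl for 4-Fluorophenyl on a Fused Core

The source may report more compounds than this note shows. Statements on the series, on what has been measured and on what is new or still open speak of the compounds shown alone.

Measured compounds:
compound 1 `Cc1ccncc1-c1cccc2c1ncn2-c1cscn1` — 90%
compound 2 `Cc1ccncc1-c1cccc2c1cnn2-c1ccc(F)cc1` — 100%

In an ADME assay on liver for metabolic stability, with Liver microsome (Homo sapiens) as the target, using microsomes, with a stated time of 10 min, tested at 0.5 uM (on this read-out lower numbers stand for a less stable compound and higher numbers for a more stable compound), compound 1 gives 90% and compound 2 gives 100%. The gap between the two lies within the usual scatter of this measurement, so neither can be called more stable than the other; compound 2 simply sits together with compound 1 at the upper end of the scale. Compound 3 `Cc1ccncc1-c1cccc2c1cnn2-c1ccccn1` has not yet been measured. It shares the core of compound 2 and differs from it in one place, namely (pyridin-2-yl in place of 4-fluorophenyl on an aromatic nitrogen). For the measured compounds named here, no pair of measured compounds shows this change, so its effect cannot be read from the data at hand. Because compound 2 already gives 100% in this assay, little room remains upward, and the expected step of a number 10 percentage points lower from compound 2 to compound 3 (within the scatter) is none beyond the scatter or a small drop. Compound 3 is therefore estimated at 90% in this assay, within 70% to 100%.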

Compound 3, percent of the compound remaining: 95%
The estimate for compound 3 lay 5 percentage points below the measured number; the range from low to high includes it.
By their numbers in this assay, from the lowest: compounds 1, 3 and 2 (each within the scatter of the next).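

For the compounds shown here, putting pyridin-2-yl in place of 4-fluorophenyl on an aromatic nitrogen gives a number 5 percentage points lower from compound 2 to compound 3 (within the scatter) in this assay, the first measured pair that differs in one place. At this position of the shared core, then, a six-membered aromatic ring of carbon only and one with a ring nitrogen read alike, although both compounds lie so near the top of the scale that a real difference could stay hidden. Nothing measured here explains this result.

The compounds shown leave open whether this position would read the same with a piperidine ring or a longer alkyl chain in place of the aromatic ring. From the compounds shown here alone, it also remains open whether pyridin-2-yl would read alike on the core of compound 1.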